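The source may hold more compounds than are shown below. What is called first, only, known or untested is meant among the compounds shown, and "the series" means these compounds.

In a functional assay on A549 cells (Homo sapiens) for inhibition, read by sulforhodamine B assay, with a stated time of 72 h (a lower number here means a stronger inhibitor of growth, a higher number a weaker inhibitor of growth), compound 3, `O=C(/C=C/c1ccncc1-c1ccc2ccccc2c1)N1CCOCC1`, gives 8410 nM. Of the two numbers shown it is the higher, though its nearest neighbour, compound 2, `CNC(=O)/C=C/c1ccncc1-c1ccc2ccccc2c1`, gives in this assay 6620 nM, and the step of a 1.3-fold higher number from compound 2 to compound 3 (0.10 log units; within the scatter) lies within the scatter, so no order between them can be read. Compound 1, `COC1CN(C(=O)/C=C/c2ccncc2-c2ccc3ccccc3c2)C1`, gives in this assay only a limit, > 10000 nM, as recorded under (the limit of > 10000 nM in this assay, at which 1 of the 3 values shown sits).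

Compound 4, `CN(C)C(=O)/C=C/c1ccncc1-c1ccc2ccccc2c1`, differs from compound 3 in one place: dimethylamino in place of morpholin-4-yl on a carbonyl carbon. Among the compounds with values here, the steps that bear on this change are those that swap the same amide substituent among compounds 1, 2 and 3: an at least 1.5-fold lower number from compound 1 to compound 2 (0.17 log units; that floor lies within the scatter), an at least 1.1-fold lower number from compound 1 to compound 3 (0.07 log units; that floor lies within the scatter) and a 1.3-fold higher number from compound 2 to compound 3 (0.10 log units; within the scatter). None of them carries this assay beyond the scatter, and the two with a floor rest on a limit rather than a number. The expectation for compound 4 is therefore no step beyond the scatter, a move of a 1.1-fold lower number from compound 3 to compound 4 (0.05 log units; within the scatter). Compound 4 is estimated at 7500 nM, expected to fall between 3500 nM and 16000 nM.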

Compound 4, concentration for 50% growth inhibition: 5800 nM
For compound 4 the middle estimate is 1.3-fold (0.11 log units) above the measured one, within the range that was stated.
By their numbers in this assay, from the lowest: compounds 4, 2 and 3 (each within the scatter of the next). At a limit, above all of these: compound 1.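

In this assay, dimethylamino on the carbonyl carbon, which has no ring, cannot be told apart from the six-membered morpholin-4-yl ring (a 1.5-fold lower number from compound 3 to compound 4 (0.16 log units; within the scatter)). Methyl in place of hydrogen on the amide-type nitrogen adds a second comparison at this position, and compound 2 and compound 4 also cannot be told apart (a 1.1-fold lower number from compound 2 to compound 4 (0.06 log units; within the scatter)). The step from compound 1 gives only a floor, and that floor lies within the scatter (an at least 1.7-fold lower number from compound 1 to compound 4 (0.23 log units; that floor lies within the scatter)).

Going by these compounds, whether a carboxylic acid, a longer chain ending in an amine or a piperazine ring on this carbonyl carbon would carry the number beyond the scatter stays open. How far compound 1 truly lies from the others also stays open, since its value is a limit and not a number: the limit of > 10000 nM in this assay, at which 1 of the 4 values shown sits.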